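The source may report more compounds than this note shows. Statements on the series, on what has been measured and on what is new or still open speak of the compounds shown alone.

Compound 2 `N=C(NCCCc1c[nH]cn1)NCCC(c1cc(F)cc(F)c1)c1ccccn1` is an agonist of the histamine type in a functional assay on muscle tissue for agonist activity at histamine H2 receptor (Cavia porcellus) (on this read-out higher numbers stand for larger maximal responses and lower numbers for smaller maximal responses), where compound 2 gives 0.8. Compound 1 `N=C(NCCCc1c[nH]cn1)NCCC(c1cccc(C(F)(F)F)c1)c1ccccn1` gives 0.7 in this assay, and the two numbers lie within the scatter of each other, as the step a number 0.10 higher from compound 1 to compound 2 (within the scatter) shows. Compound 3 `N=C(NCCCc1c[nH]cn1)NCCC(c1ccc(Cl)c(Cl)c1)c1ccccn1` differs from compound 2 in one place: 3,4-dichlorophenyl in place of 3,5-difluorophenyl on a saturated chain carbon bound to an aromatic carbon and a saturated chain carbon. Within the data shown here, only one measured step bears on this change, the step from compound 1 to compound 2, which also exchanged the ring at this place and stayed within the scatter. A step of about that size is therefore expected here, with no change beyond the scatter: no change at the digits printed from compound 2 to compound 3 (within the scatter). Compound 3 is estimated at 0.8, between 0.6 and 0.9.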

Compound 3, intrinsic activity: the largest response reached, as a fraction of the reference agonist's: 0.8
Beside the measured number, compound 3's estimate shows no gap at the digits printed, and the stated range covers the measured number.
By their numbers in this assay, from the lowest: compounds 1, 2 and 3 (each within the scatter of the next).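

In this assay, 3,4-dichlorophenyl on this saturated chain carbon gives no change at the digits printed from compound 2 to compound 3 (within the scatter) when it takes the place of 3,5-difluorophenyl, and a number 0.10 higher from compound 1 to compound 3 (within the scatter) when it takes the place of 3-(trifluoromethyl)phenyl. Among these compounds, all three substituted rings at this place now give numbers within the scatter of each other, where earlier only one pair could be compared. No measurement shown here offers an explanation for this. Still open, from the compounds shown here alone, is what happens when the ring at this place carries an amine or a carboxylic acid, or no substituent at all.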